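The source may hold more compounds than are shown below. What is called first, only, known or untested is meant among the compounds shown, and "the series" means these compounds.

Measured compounds in an ADME assay on TZM-b1 cells (Homo sapiens) for cytotoxicity, read by XTT assay, with a stated time of 3 days; on this read-out lower numbers stand for higher toxicity in this test and higher numbers for lower toxicity in this test:
compound 1 `Cc1nc(C(NC(=O)C(=O)Nc2ccc(F)cc2)C2CCCCN2)sc1CCO`: > 88000 nM
compound 2 `Cc1nc(C(NC(=O)C(=O)Nc2ccc(Cl)cc2)C2CCCCN2)sc1CCO`: 32800 nM
compound 3 `Cc1nc(C(NC(=O)C(=O)NC2CCCCCC2)C2CCCCN2)sc1CCO`: > 88000 nM

Compound 3 sits at the limit of the assay rather than at a number; its value in this assay is a limit, and the limit of > 88000 nM in this assay, at which 2 of the 3 values shown sit, holds for it. Compound 1 also returns only a limit in this assay. For the measured compounds named here, compound 2 is the one compound with a measured number, and the step of an at least 2.6-fold higher number from compound 2 to compound 3 (0.42 log units; beyond the scatter) is therefore the only readable step into compound 3; the step that the two limits leave unreadable from compound 1 to compound 3 cannot be sized. Within the anilide pair, the step of an at least 2.6-fold lower number from compound 1 to compound 2 (0.42 log units; beyond the scatter) is beyond the scatter, chloro in place of fluoro on an aromatic carbon.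

Compound 4 `Cc1nc(C(NC(=O)C(=O)Nc2ccc(Cl)c(F)c2)C2CCCCN2)sc1CCO` carries the change (4-chloro-3-fluorophenyl in place of cycloheptyl on an amide-type nitrogen). The step from compound 2 to compound 3 ran in the opposite sense of the change now made, and compound 4 keeps the chloro of compound 2 while adding a fluoro on the same ring. The expectation is therefore a lower number in this assay for compound 4 than the limit of compound 3, of roughly the size seen in an at least 2.6-fold higher number from compound 2 to compound 3 (0.42 log units; beyond the scatter) but reversed, so that an at least 2.9-fold lower number from compound 3 to compound 4 (0.46 log units; beyond the scatter) is expected. Compound 4 is estimated at 30000 nM, with a range from 9000 nM to 90000 nM.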

Compound 4, half-maximal cytotoxic concentration: 61000 nM
Beside the measured number, compound 4's estimate is 2.0-fold (0.31 log units) below it, and the stated range covers the measured number.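

In this assay, fluoro in place of hydrogen on an aromatic carbon gives a 1.9-fold higher number from compound 2 to compound 4 (0.27 log units; within the scatter), so adding this fluoro to the chlorinated ring leaves the read-out within the scatter. On the amide-type nitrogen, 4-chloro-3-fluorophenyl in place of cycloheptyl gives an at least 1.4-fold lower number from compound 3 to compound 4 (0.15 log units; that floor lies within the scatter), and in place of 4-fluorophenyl it gives an at least 1.4-fold lower number from compound 1 to compound 4 (0.15 log units; that floor lies within the scatter); neither floor clears the scatter, so the measured number does not separate this ring from either group. Chloro on the aromatic ring therefore no longer tracks a clear step: compound 2 has steps beyond the scatter to both limit compounds, whereas compound 4, which also carries chloro, goes against that pattern.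

As far as these compounds go, how far compound 1 and compound 3 actually lie from compound 4 cannot be read, since each returns only a limit: the limit of > 88000 nM in this assay, at which 2 of the 4 values shown sit. Also open is how this assay would read with an amine or a carboxylic acid on the aromatic ring, or with a longer chain in place of the ring on the amide-type nitrogen.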